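A few compounds are considered here, and "the series" means these few. Any claim that something is new, unique, unknown or untested is made for them only; others in the source may bear on it.

Measured so far:
- Compound 1 `O=C(CCCCC1CCSS1)Nc1cccc(C(F)(F)F)c1`: "not active" (no number reported)
- Compound 2 `O=C(CCCCC1CCSS1)Nc1ccccn1`: 0.89%

Going by the values given here, in a functional assay on Bel-7402 cells (Homo sapiens) for inhibition, read by MTT assay, with a stated time of 24 h, tested at 0.1 ug/mL (a lower number here means less inhibition of growth, a higher number more inhibition of growth at the concentration tested), compound 2 gives 0.89%, the only number available. Compound 1 is reported as "not active" (no number reported), with no number to compare, so compound 2 cannot be ranked in any meaningful way.

Compound 3 `O=C(CCCCC1CCSS1)Nc1ccc(Br)cn1` differs from compound 2 in one place: bromo in place of hydrogen on an aromatic carbon. The bromo takes the place of a hydrogen on an aromatic carbon, two atoms from the ring nitrogen. Among the compounds with values here, no measured pair shows what a single change does in this assay, so there is little to guide a prediction. The starting point is compound 2 at 0.89%, close to no inhibition. The expected a number 3.1 percentage points higher from compound 2 to compound 3 (within the scatter) is a small rise, not beyond the usual scatter. Compound 3 is estimated at 4%, with an expected range of 0% to 15%.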

Compound 3, percent growth inhibition at one concentration: "not active" (no number reported)
Compound 3 has no reported number here; no gap can be computed for the estimate.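

In this assay, going by these compounds alone, compound 3 gives "not active" (no number reported) and so, with compound 2, it yields no step that can be read. Within the data shown here, what the bromo changes in growth inhibition stays open, since compound 1, compound 2 and compound 3 offer no pair with two numbers. No measured evidence bears on this result.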